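This account rests on a few compounds, and the source may have more. Where it says the series, first, only, none or still open, it means among the compounds named here.

Working notes on the series. Of the compounds shown here, three of the shared core have been measured in a functional assay on B16 cells (Mus musculus) for cytotoxicity, read by MTT assay, with a stated time of 72 h; a lower number here means a stronger inhibitor, a higher number a weaker inhibitor. Compound 1 `COc1c(OCCCCN2CCN(C)CC2)cc(O)c2c(=O)cc(-c3ccc(F)cc3)oc12` gives 4320 nM in this assay. Compound 2 `CN(C)CCCOc1c(OCc2ccccc2)cc(O)c2c(=O)cc(-c3ccccc3)oc12` gives 5420 nM in this assay. Compound 3 `CN1CCN(CCCCOc2c(OCc3ccc(C#N)cc3)cc(O)c3c(=O)cc(-c4ccccc4)oc23)CC1` gives 3700 nM in this assay. The number for compound 3 is the lowest of the three, but its gaps to compound 1 and to compound 2 both sit within the scatter of repeated measurements, so the three values are read as equivalent, and none of the three can be called the most potent. No pair of these compounds differs in a single place, so no isolated structural step has been measured, and nothing in the set shows how a change at the benzyloxy position moves the number.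

The next compound, compound 4 `CN1CCN(CCCCOc2c(OCc3nc4ccccc4o3)cc(O)c3c(=O)cc(-c4ccccc4)oc23)CC1`, is not yet measured in this assay. Against compound 3 the change is 1,3-benzoxazol-2-yl in place of 4-cyanophenyl on a saturated chain carbon bound to an oxygen on an aromatic ring. Within the data shown here, with no measured step for guidance, the expectation rests on the narrow band the three measured values occupy: the step from compound 3 to compound 4 is expected to be small, a 1.1-fold higher number from compound 3 to compound 4 (0.03 log units; within the scatter), with no clear direction beyond the scatter. For compound 4 in this assay the estimate is 4000 nM, with a range from 1800 nM to 9000 nM.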

Compound 4, half-maximal inhibitory concentration: 2080 nM
Beside the measured number, compound 4's estimate is 1.9-fold (0.28 log units) above it, and the stated range covers the measured number.
By their numbers in this assay, from the lowest: compounds 4, 3, 1 and 2 (each within the scatter of the next, the first and the last beyond it).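

Among these compounds, the first isolated step falls at this position: in this assay, putting 1,3-benzoxazol-2-yl in place of 4-cyanophenyl on a saturated chain carbon bound to an oxygen on an aromatic ring gives a 1.8-fold lower number from compound 3 to compound 4 (0.25 log units; within the scatter) and so stays inside the usual spread of repeat measurements. The position therefore tolerates this exchange in this read-out, even though the exchange replaces a nitrile-bearing six-membered aromatic ring of carbon only with a group holding a five-membered aromatic ring with 2 hetero atoms and a six-membered aromatic ring of carbon only. No independent data bear on this result, so the step stands as an observation without an explanation.

Still open, from the compounds shown here alone, is whether a simple unsubstituted phenyl or a pyridine ring at this place would stay in the same band, which would show how much the nitrile or the second ring counts for anything here. Also open, going by these compounds, is whether a propyl or a longer pentyl chain to the amine would move the number once the group at this position is held fixed as 1,3-benzoxazol-2-yl.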